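Swapping cyclohexyl for pyrimidin-2-yl on the ring nitrogen

A few compounds are considered here, and "the series" means these few. Any claim that something is new, unique, unknown or untested is made for them only; others in the source may bear on it.

Three compounds share one core and differ only in the group on an aromatic nitrogen. In a functional assay on HT-29 cells (Homo sapiens) for inhibition, read by luminescence and CellTiter-Glo, with a stated time of 24 h (a lower number here means that less compound is needed, a higher number that more compound is needed for the effect), compound 1 `CN1C(=S)[C@@H](NC(=O)c2nc(Cc3ccccc3)n(C)n2)COc2ccccc21` gives 2.5 nM. Compound 2 `CN1C(=S)[C@@H](NC(=O)c2nc(Cc3ccccc3)n(C3CCC3)n2)COc2ccccc21` gives 181 nM, and compound 3 `CN1C(=S)[C@@H](NC(=O)c2nc(Cc3ccccc3)n(C3CCCCC3)n2)COc2ccccc21` gives 4000 nM, the highest of the three numbers, with large steps a 72-fold higher number from compound 1 to compound 2 (1.86 log units; beyond the scatter), a 1600-fold higher number from compound 1 to compound 3 (3.20 log units; beyond the scatter) and a 22-fold higher number from compound 2 to compound 3 (1.34 log units; beyond the scatter). Compound 4 `CN1C(=S)[C@@H](NC(=O)c2nc(Cc3ccccc3)n(-c3ncccn3)n2)COc2ccccc21` carries pyrimidin-2-yl in place of cyclohexyl on an aromatic nitrogen. For the measured compounds named here, none of the measured steps exchanges a saturated carbon ring for an aromatic one, so they bear on this change only loosely; the entering group matches cyclohexyl in heavy-atom count but adds two acceptors. Compound 4 is therefore expected to give about 1000 nM, within 100 nM to 8000 nM. This expectation corresponds to a step of a 4.0-fold lower number from compound 3 to compound 4 (0.60 log units; beyond the scatter).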

Compound 4, half-maximal effective concentration: 3970 nM
For compound 4 the middle estimate is 4.0-fold (0.60 log units) below the measured one; low and high end bracket the measured number.
By their numbers in this assay, from the lowest: compound 1; then compound 2; then compounds 4 and 3 (each within the scatter of the next).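

In this assay, an aromatic ring carrying hydrogen-bond acceptors on this aromatic nitrogen cannot be told apart from the saturated carbon ring of the same heavy-atom count (a 1.0-fold lower number from compound 3 to compound 4 (0.00 log units; within the scatter)). Pyrimidin-2-yl therefore shares with cyclohexyl the large distance from methyl (a 1600-fold higher number from compound 1 to compound 4 (3.20 log units; beyond the scatter)) and from cyclobutyl (a 22-fold higher number from compound 2 to compound 4 (1.34 log units; beyond the scatter)). No evidence is available that bears on this result. As far as these compounds go, it remains open whether phenyl, which has no ring nitrogen, would read like pyrimidin-2-yl. From the compounds shown here alone, it also remains open whether ethyl would stay close to methyl.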